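This account rests on a few compounds, and the source may have more. Where it says the series, first, only, none or still open, it means among the compounds named here.

Measured compounds:
Compound 1 `CCc1cc(C(C)=O)c(O)cc1OCCCCCC(C)(C)C#N`: 53%
Compound 2 `CC(=O)c1cc(C(C)(C)C)c(OCCCCCC(C)(C)C#N)cc1O`: 2%

In an assay on isolated protein for binding affinity to leukotriene B4 receptor 1 (Homo sapiens), tested at 1 uM (a lower number here means less inhibition, a higher number more inhibition at the concentration tested (going by the name of the read-out)), compound 1 gives 53%, the highest of the two numbers; compound 2 gives 2%, a step of a number 51 percentage points lower from compound 1 to compound 2 (beyond the scatter). Compound 3 `CCc1cc(C(C)=O)c(O)cc1OCCCCCCSC` differs from compound 1 at the chain end: (methylsulfanyl)methyl in place of 1-cyano-1-methylethyl on a saturated chain carbon, five bonds along the chain from an oxygen on an aromatic ring. Within the data shown here, the only measured step changes a group on the aromatic ring, not the chain, so it does not bear on this change, and no step beyond the scatter in either direction is expected, only wide uncertainty. Compound 3 is therefore estimated at 42%, between 10% and 75%, a step of a number 11 percentage points lower from compound 1 to compound 3 (beyond the scatter).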

Compound 3, a percentage reported as inhibition, at one concentration (the size of the read-out at that concentration, not a potency): 14%
Compound 3: the middle estimate sits 28 percentage points above what was measured, within the range that was stated.
By their numbers in this assay, from the lowest: compound 2; then compound 3; then compound 1.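

Among these compounds, the chain end also counts: in this assay, replacing 1-cyano-1-methylethyl with (methylsulfanyl)methyl gives a number 39 percentage points lower from compound 1 to compound 3 (beyond the scatter) and shows that a change far along the chain, not only one on the aromatic ring, can move this number beyond the scatter. Of this pair, the chain ending in the nitrile gives the higher number. No measured evidence here explains the drop.

As far as these compounds go, because this change replaces the nitrile and its two branching methyl groups together, their separate contributions remain open. From the compounds shown here alone, how a chain ending in an amine or a carboxylic acid would compare also remains unknown.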